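A few compounds are considered here, and "the series" means these few. Any claim that something is new, unique, unknown or untested is made for them only; others in the source may bear on it.

Measured compounds:
compound 1 `O=C(/C=C/c1ccc(N2CCCC2)cc1)c1ccc(O)cc1`: 60%
compound 2 `COc1ccc(/C=C/C(=O)c2ccc(F)cc2)cc1Br`: 20.1%
compound 3 `O=C(/C=C/c1ccc(N2CCCC2)cc1)c1ccc(F)cc1`: 73.1%

In an assay on isolated protein for inhibition of DNA topoisomerase 1 (Homo sapiens), tested at 20 uM (on this read-out lower numbers stand for a weaker effect and higher numbers for a stronger effect at the one concentration tested), compound 1 stands second highest of the three, beyond the scatter from compound 3 above it and far beyond it from compound 2 below. Compound 4 `O=C(/C=C/c1ccc(F)cc1)c1ccc(O)cc1`, not yet measured, differs from compound 1 in one place: fluoro in place of pyrrolidin-1-yl on an aromatic carbon. Going by the values given here, no measured step swaps this group; the only measured step, a number 13.1 percentage points higher from compound 1 to compound 3 (beyond the scatter), concerns the other ring and bears only loosely. Compound 2, which lacks pyrrolidin-1-yl, gives 20.1%. Compound 4 is therefore expected to fall, with a step of a number 25 percentage points lower from compound 1 to compound 4 (beyond the scatter). The inhibition of compound 4 is estimated at 35%, in the range 15% to 60%.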

Compound 4, a percentage reported as inhibition, at one concentration (the size of the read-out at that concentration, not a potency): 18%
Compound 4: the middle estimate sits 17 percentage points above what was measured, and the stated range covers the measured number.
By their numbers in this assay, from the lowest: compounds 4 and 2 (each within the scatter of the next); then compound 1; then compound 3.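

In this assay, going by these compounds alone, the aromatic position para to a large group, which no earlier step had touched, turns out to matter: the change gives a number 42 percentage points lower from compound 1 to compound 4 (beyond the scatter), a large step set against the modest one on the other ring, a number 13.1 percentage points higher from compound 1 to compound 3 (beyond the scatter). With hydroxy on the other ring, fluoro does not keep what pyrrolidin-1-yl gives at this position. Nothing available explains this loss.

Going by these compounds, whether the ring or its nitrogen counts remains open, and a dimethylamino group, a piperidine or a morpholine here would separate the two. Also open, on these data alone, is whether the same loss holds with fluoro on the other ring.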